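The source may report more compounds than this note shows. Statements on the series, on what has been measured and on what is new or still open speak of the compounds shown alone.

Measured compounds:

Compound 1, `O=C(O)C1=C(Nc2ccc(Br)cc2)OCC1=O`: 39%
Compound 2, `O=C(O)C1=C(Nc2cccc(C(F)(F)F)c2)OCC1=O`: 40%

Both values come from a functional assay on the whole organism for inhibition, with Rattus norvegicus as the target, with a stated time of 1 h, at a dose of 100 mg/kg by the oral route; a higher number here means more inhibition at the dose given (going by the name of the read-out), a lower number less inhibition. Compound 1 carries a bromine on its aryl ring, compound 2 a trifluoromethyl group on its aryl ring, and the two share the rest of their core. Compound 2 gives the higher of the two numbers, but its nearest neighbour, compound 1, lies a single point lower, a gap that sits inside the usual scatter, so the two readings cannot be told apart.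

Compound 3, `CCOC(=O)C1=C(Nc2cccc(C(F)(F)F)c2)OCC1=O`, is not yet measured. It differs from compound 2 in one place: ethyl in place of hydrogen on an oxygen next to a carbonyl group. Cut one bond further out, the change reads carboxy to ethoxycarbonyl.

For the measured compounds named here, no measured pair here shows this change, so its effect in this assay is unknown from these data. A modest shift in either direction, or none beyond the scatter, is the expectation. The step of a number 5 percentage points lower from compound 2 to compound 3 (within the scatter) is therefore expected to be small. For compound 3 the estimated value is 35%, within a range from 10% to 62%.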

Compound 3, a percentage reported as inhibition, in the whole organism at one dose (the size of the read-out at that dose, not a potency): 9.7%
Estimate against measurement, compound 3: 25.3 percentage points above, and the stated range ends above it.
By their numbers in this assay, from the lowest: compound 3; then compounds 1 and 2 (each within the scatter of the next).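

The earlier compounds shown here both carried the carboxy group and differed only on the aryl ring, so they said nothing about this end of the molecule. Here, in this assay, ethyl in place of hydrogen on an oxygen next to a carbonyl group gives a number 30.3 percentage points lower from compound 2 to compound 3 (beyond the scatter) and so marks this position as one where a single change moves the read-out well beyond the scatter, at least with trifluoromethyl on the aryl ring. Nothing measured here explains the drop, and no supporting data bear on why this change has so large an effect.

For the compounds shown here, the single pair cannot separate the loss of the hydrogen from the arrival of the ethyl, a question that a methyl ester, a longer chain such as a butyl ester, or a primary amide in the same place would bear on. Going by these compounds, whether ethoxycarbonyl has a similar effect alongside the bromine of compound 1 also remains open, as does the outcome with a tetrazole in place of the carboxy group.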